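Adding a Methyl to the Core of Compound 1

A few compounds are considered here, and "the series" means these few. Any claim that something is new, unique, unknown or untested is made for them only; others in the source may bear on it.

Of the compounds shown here, two have so far been measured in an assay on MOLT-4 cells for inhibition of integrin alpha-4/beta-1 (Homo sapiens); on this read-out higher numbers stand for weaker inhibition and lower numbers for stronger inhibition. Compound 1, `NC(=O)C1(NC(=O)[C@@H](CCCC(=O)O)NC(=O)[C@@H](CCCCNC(=O)/C=C/c2cccnc2)NC(=O)c2ccc(Nc3nc4ccccc4[nH]3)cc2)CCCCC1`, gives 420 nM in this assay. Compound 2, `NC(=O)C1(NC(=O)[C@@H](CCCC(=O)O)NC(=O)[C@@H](CCCCNC(=O)/C=C/c2cccnc2)NC(=O)CCc2ccc(Nc3nc4ccccc4[nH]3)cc2)CCCCC1`, gives 344 nM in this assay. These two numbers lie within the usual scatter of repeated measurements of each other, so nothing separates them, and compound 1 simply stands as one of the two compounds with a known number.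

Compound 3, `Cc1cccc2[nH]c(Nc3ccc(C(=O)N[C@H](CCCCNC(=O)/C=C/c4cccnc4)C(=O)N[C@H](CCCC(=O)O)C(=O)NC4(C(N)=O)CCCCC4)cc3)nc12`, has not yet been measured. It differs from compound 1 in one place: methyl in place of hydrogen on an aromatic carbon. Within the data shown here, no pair of measured compounds shows what a change of this kind does here, so there is no measured step to lean on. A single methyl added to the core of compound 1 is a small alteration, and the expected step is a 1.2-fold lower number from compound 1 to compound 3 (0.08 log units; within the scatter), a change not beyond the scatter. Compound 3 is therefore expected to give about 350 nM in this assay, with a likely range from 120 nM to 1000 nM.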

Compound 3, half-maximal inhibitory concentration in the integrin alpha-4/beta-1 assay: 27.5 nM
Compound 3: the middle estimate sits 13-fold (1.10 log units) above what was measured, and the stated range ends above it.
By their numbers in the integrin alpha-4/beta-1 assay, from the lowest: compound 3; then compounds 2 and 1 (each within the scatter of the next).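

Replacing 1H-benzimidazol-2-yl with 4-methyl-1H-benzimidazol-2-yl gives, in the integrin alpha-4/beta-1 assay, a 15-fold lower number from compound 1 to compound 3 (1.18 log units; beyond the scatter). Before this result, no pair of compounds showed what a change at this place does; now it is clear that adding one carbon to this aromatic ring, on a carbon ortho to a fused ring, can strongly change inhibition even though the rest of the molecule stays the same. The same change also shifts the result in a physicochemical assay for lipophilicity; on this read-out lower numbers stand for lower lipophilicity and higher numbers for higher lipophilicity: the measured partition coefficient of compound 1, 1.83, and of compound 3, 2.58, a number 0.75 log units higher (beyond the scatter) In the physicochemical assay compound 1 gives 1.83 and compound 3 gives 2.58.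

This single pair cannot show whether the stronger inhibition is tied to the higher partition coefficient or to some other feature of the added methyl. Nor do the compounds shown reveal whether an ethyl group, a chlorine atom or a methoxy group on this same carbon would give a similar result, or whether a methyl on another aromatic carbon of this ring would do so.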